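Urea variation on the oxadiazole-piperidine series: cyclohexyl to sulfone

The compounds below may be only part of what the source reports. "The series", "measured", "known", "first", "only" and "open" are said of these compounds alone.

Measured so far in a functional assay on Shh Light II cells (Mus musculus) for inhibition, read by a luciferase reporter; on this read-out higher numbers stand for weaker inhibition and lower numbers for stronger inhibition:
- compound 1 `COc1ccccc1NC(=O)N1CCC(c2nc(-c3ccc4ccccc4n3)no2)CC1`: 410 nM
- compound 2 `Cn1c(-c2noc(C3CCN(C(=O)NC4CCS(=O)(=O)CC4)CC3)n2)nc2ccccc21`: 350 nM
- compound 3 `O=C(NC1CCCCC1)N1CCC(c2nc(-c3ccc4ccccc4n3)no2)CC1`: 57 nM

Compound 3 gives the lowest number of the three in this assay, and both of its gaps to compound 1 and compound 2 lie beyond the scatter, so it is the strongest inhibitor seen here. Among the compounds with values here, the one step within the set, a 7.2-fold lower number from compound 1 to compound 3 (0.86 log units; beyond the scatter), shows how much the group on the urea nitrogen can move the number.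

The next compound, compound 4 `O=C(NC1CCS(=O)(=O)CC1)N1CCC(c2nc(-c3ccc4ccccc4n3)no2)CC1`, keeps the core of compound 3 and carries the change (1,1-dioxothian-4-yl in place of cyclohexyl on an amide-type nitrogen). Within the data shown here, no measured pair isolates this exact change. Compound 2 bears the same 1,1-dioxothian-4-yl group on a different core, and compound 2 in this assay gives 350 nM, while compound 3 gives 57 nM; that comparison mixes two changes and can only hint. The expectation for compound 4 is therefore a higher number, with a step of about a 2.8-fold higher number from compound 3 to compound 4 (0.45 log units; beyond the scatter). Compound 4 is estimated at 160 nM in this assay, with a range from 50 nM to 500 nM.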

Compound 4, half-maximal inhibitory concentration: 360 nM
Estimate against measurement, compound 4: 2.3-fold (0.35 log units) below; the range from low to high includes it.
By their numbers in this assay, from the lowest: compound 3; then compounds 2, 4 and 1 (each within the scatter of the next).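

In this assay the swap at the amide-type nitrogen gives a 6.3-fold higher number from compound 3 to compound 4 (0.80 log units; beyond the scatter) and so costs inhibition on the shared core, while a 1.1-fold lower number from compound 1 to compound 4 (0.06 log units; within the scatter) leaves 1,1-dioxothian-4-yl and 2-methoxyphenyl unseparated, with cyclohexyl alone ahead of both. With 1,1-dioxothian-4-yl in place, the change of aromatic group gives a 1.0-fold higher number from compound 2 to compound 4 (0.01 log units; within the scatter) and does not separate quinolin-2-yl from 1-methyl-1H-benzimidazol-2-yl. Nothing available explains the loss seen with 1,1-dioxothian-4-yl.

Open, from the compounds shown here alone, is whether the sulfone itself or the ring as a whole sets this loss, which tetrahydropyran-4-yl or 4-hydroxycyclohexyl on the same nitrogen could help to separate. Also open, going by these compounds, is whether cyclohexyl keeps its lead when paired with 1-methyl-1H-benzimidazol-2-yl on the aromatic carbon.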